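The source may hold more compounds than are shown below. What is called first, only, known or untested is meant among the compounds shown, and "the series" means these compounds.

Compound 1 `OC[C@H]1O[C@@H](n2cc(F)c3c(-c4ccccc4)ncnc32)[C@H](O)[C@@H]1O`: > 40000 nM (a limit)
Compound 2 `OC[C@H]1O[C@@H](n2cc(F)c3c(-c4cccs4)ncnc32)[C@H](O)[C@@H]1O`: 4300 nM
Compound 3 `OC[C@H]1O[C@@H](n2cc(F)c3c(-c4ccc[nH]4)ncnc32)[C@H](O)[C@@H]1O`: 3300 nM

In a functional assay on HL-60 cells (Homo sapiens) for cytotoxicity, read by XTT assay, with a stated time of 3 days (on this read-out lower numbers stand for stronger inhibition and higher numbers for weaker inhibition), the value for compound 1 is only a limit (the limit of > 40000 nM in this assay, at which 1 of the 3 values shown sits). Compound 3 gives 3300 nM, and its thiophen-2-yl counterpart sits level with it: a 1.3-fold lower number from compound 2 to compound 3 (0.11 log units; within the scatter). Compound 4 `OC[C@H]1O[C@@H](n2cc(F)c3c(-c4ccsc4)ncnc32)[C@H](O)[C@@H]1O` carries thiophen-3-yl in place of 1H-pyrrol-2-yl on an aromatic carbon. Replacing phenyl gave large gains: an at least 9.3-fold lower number from compound 1 to compound 2 (0.96 log units; beyond the scatter) and an at least 12-fold lower number from compound 1 to compound 3 (1.08 log units; beyond the scatter). Compound 4 keeps a five-membered aromatic ring, and exchanging such rings has so far shifted little: a 1.3-fold lower number from compound 2 to compound 3 (0.11 log units; within the scatter). No step beyond the scatter is therefore expected, and the estimated step is a 1.2-fold higher number from compound 3 to compound 4 (0.08 log units; within the scatter). Compound 4 is estimated at 4000 nM, with an expected range of 1500 nM to 12000 nM.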

Compound 4, half-maximal inhibitory concentration: 4900 nM
Estimate against measurement, compound 4: 1.2-fold (0.09 log units) below; low and high end bracket the measured number.
By their numbers in this assay, from the lowest: compounds 3, 2 and 4 (each within the scatter of the next). At a limit, above all of these: compound 1.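

Thiophen-3-yl and thiophen-2-yl read alike at this position in this assay (a 1.1-fold higher number from compound 2 to compound 4 (0.06 log units; within the scatter)). Exchanging 1H-pyrrol-2-yl, which has a hydrogen-bond donor, for thiophen-3-yl, which has none, also stays within the scatter (a 1.5-fold higher number from compound 3 to compound 4 (0.17 log units; within the scatter)), so that donor shows no measurable effect on this read-out. The step away from phenyl extends to a third five-membered ring (an at least 8.1-fold lower number from compound 1 to compound 4 (0.91 log units; beyond the scatter)), though it rests on a limit for compound 1.

On these data alone, whether a furan-2-yl or a thiazol-2-yl group would stay level with these rings remains open. So does whether a non-aromatic group, such as an amine, would retain any of the gain over phenyl.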